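A Trifluoromethyl Swap on a Growth Inhibitor

A few compounds are considered here, and "the series" means these few. Any claim that something is new, unique, unknown or untested is made for them only; others in the source may bear on it.

In a functional assay on A375P cells (Homo sapiens) for inhibition, read by MTT assay, with a stated time of 24 h (on this read-out higher numbers stand for weaker inhibition of growth and lower numbers for stronger inhibition of growth), compound 1 (`COc1ccc(Cn2ncc3c2NC(=O)CC(c2ccc(NC(=O)Nc4ccc(Cl)c(C(F)(F)F)c4)cc2)=N3)cc1`) gives 3930 nM. Compound 2 (`COc1ccc(Cn2ncc3c2NC(=O)CC(c2cccc(NC(=O)Nc4cccc(Cl)c4)c2)=N3)cc1`) gives 910 nM, the lower of the two numbers, and the gap between them lies beyond the scatter. Compound 3 (`COc1ccc(Cn2ncc3c2NC(=O)CC(c2cccc(NC(=O)Nc4ccc(C(F)(F)F)cc4)c2)=N3)cc1`) is still unmeasured. It has 4-(trifluoromethyl)phenyl in place of 3-chlorophenyl on an amide-type nitrogen. Among the measured compounds shown here, no measured pair isolates this change, and the only guide is that compound 1, which also carries trifluoromethyl, stands at 3930 nM. A modest weakening is therefore expected, an estimated 1.6-fold higher number from compound 2 to compound 3 (0.22 log units; within the scatter), which may stay within the scatter. The estimate for compound 3 is 1500 nM, with a range of 550 nM to 4200 nM.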

Compound 3, concentration for 50% growth inhibition: 770 nM
The estimate for compound 3 lay 1.9-fold (0.29 log units) above the measured number; measured number inside the range.
By their numbers in this assay, from the lowest: compounds 3 and 2 (each within the scatter of the next); then compound 1.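

In this assay, placing 4-(trifluoromethyl)phenyl in place of 3-chlorophenyl on an amide-type nitrogen gives a 1.2-fold lower number from compound 2 to compound 3 (0.07 log units; within the scatter), so the two groups read alike here. At this position, then, trifluoromethyl does not by itself bring a weaker number. No outside evidence explains this result.

The compounds shown do not separate the exchange of chlorine for trifluoromethyl from the shift from 3 to 4 in the group's name. As far as these compounds go, how an amine or a carboxylic acid on this ring would read also remains open.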